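A few compounds are considered here, and "the series" means these few. Any claim that something is new, unique, unknown or untested is made for them only; others in the source may bear on it.

Compounds measured so far:
compound 1 `CN1CCN(Cc2ccc(NC(=O)Nc3ccc4ncnc(Nc5cccc(C(F)(F)F)c5)c4c3)cc2)CC1` — 2410 nM in a functional assay on A-431 cells (Homo sapiens) for antiproliferative activity, read by MTT assay, with a stated time of 72 h; on this read-out higher numbers stand for weaker inhibition and lower numbers for stronger inhibition
compound 2 `CN(C)Cc1ccc(NC(=O)Nc2ccc3ncnc(Nc4cccc(C(F)(F)F)c4)c3c2)cc1` — 1030 nM in this assay

Among the compounds with values here, compound 2 stands at the lowest of the two numbers in this assay; its only neighbour is compound 1, and the step of a 2.3-fold lower number from compound 1 to compound 2 (0.37 log units; beyond the scatter) lies beyond the scatter, though it is modest in size.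

Compound 3 `O=C(Nc1ccccc1)Nc1ccc2ncnc(Nc3cccc(C(F)(F)F)c3)c2c1` is not yet measured. It differs from compound 2 in one place: hydrogen in place of (dimethylamino)methyl on an aromatic carbon. Within the data shown here, only one measured step bears on this change, and only loosely: a 2.3-fold lower number from compound 1 to compound 2 (0.37 log units; beyond the scatter) shows that trimming the group on this saturated chain carbon from 4-methylpiperazin-1-yl to dimethylamino gave a modestly lower number. Whether cutting the (dimethylamino)methyl away altogether continues in that direction or reverses it cannot be read from two compounds, so no step beyond the scatter is expected in either direction. Compound 3 is therefore estimated at 900 nM in this assay, with a range from 250 nM to 3500 nM. The expected step of a 1.1-fold lower number from compound 2 to compound 3 (0.06 log units; within the scatter) is thus small, and its direction is uncertain.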

Compound 3, half-maximal inhibitory concentration: > 10000 nM
Compound 3: a limit, no number (the forecaster's own chance of this, stated with the estimate: 5%); middle value at least 11-fold (1.04 log units) from the limit.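

In this assay compound 3 gives only a limit of the assay and not a number: the limit of > 10000 nM in this assay, at which 1 of the 3 values shown sits. The two earlier compounds both carry an amine on a methyl group at this aromatic carbon and showed only that exchanging one amine for the other gives a modest step, whereas replacing the whole group with hydrogen gives an at least 9.7-fold higher number from compound 2 to compound 3 (0.98 log units; beyond the scatter) and likewise an at least 4.1-fold higher number from compound 1 to compound 3 (0.61 log units; beyond the scatter). So the group at this place matters to the read-out far beyond the choice between 4-methylpiperazin-1-yl and dimethylamino, and the direction of the earlier step says nothing about what happens when the group is removed altogether.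

The full size of both new steps stays unknown, since they rest on a limit, and the compounds shown cannot separate the part played by the amine nitrogen from that of the carbon and the bulk it comes with. A plain methyl group, a hydroxymethyl group or a morpholine ring on the same methyl carbon would be needed to tell these apart, and a longer chain to the amine would show whether its distance from the aromatic ring counts.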